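Cyclohexyl in place of 1-methylpiperidin-4-yl on the amide

The compounds below may be only part of what the source reports. "The series", "measured", "known", "first", "only" and "open" are said of these compounds alone.

Compound 1 `Cc1noc(C)c1-c1nn(Cc2ccc(C(=O)N3CCCCC3)cc2)c(=O)c2ccccc12` in a functional assay on A549 cells (Homo sapiens) for antiproliferative activity, read by MTT assay, with a stated time of 72 h (a higher number here means a weaker inhibitor, a lower number a stronger inhibitor), gives 86200 nM (a measured number)
Compound 2 `Cc1noc(C)c1-c1nn(Cc2ccc(C(=O)NC3CCN(C)CC3)cc2)c(=O)c2ccccc12` in this assay gives > 100000 nM (a limit of the assay, not a number)

Compound 2 has only the limit > 100000 nM in this assay and no number of its own. This is the situation recorded as the limit of > 100000 nM in this assay, at which 1 of the 2 values shown sits, for the pair measured so far.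

Compound 3 `Cc1noc(C)c1-c1nn(Cc2ccc(C(=O)NC3CCCCC3)cc2)c(=O)c2ccccc12` is the next entry, and it differs from compound 2 by cyclohexyl in place of 1-methylpiperidin-4-yl on an amide-type nitrogen. In words, cyclohexyl stands in place of 1-methylpiperidin-4-yl on an amide-type nitrogen.

For the measured compounds named here, one measured step bears on this change, namely an at least 1.1-fold higher number from compound 1 to compound 2 (0.06 log units; that floor lies within the scatter). That step also alters the group on the carbonyl carbon, and it gives no shift beyond the scatter. No step beyond the scatter is therefore expected in this assay, and no direction is firmly indicated, although a reported number would have to lie on the lower side of the limit.

Compound 3 is expected at 70000 nM, with an estimated range of 25000 nM to 100000 nM in this assay. The estimate corresponds to an expected change an at least 1.4-fold lower number from compound 2 to compound 3 (0.15 log units; that floor lies within the scatter) in this series.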

Compound 3, half-maximal inhibitory concentration: > 100000 nM
Compound 3 ended at the assay's limit; the forecaster's own chance of this, stated with the estimate: 35%; at least 1.4-fold (0.15 log units) between middle value and limit.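

In this assay compound 3 gives > 100000 nM, which is a limit of the assay and not a number. Exchanging 1-methylpiperidin-4-yl for cyclohexyl on the amide-type nitrogen therefore brings no measurable value, so a ring of carbon only at this place does not bring the series back into the readable range, and the step between compound 2 and compound 3 cannot be read: the limit of > 100000 nM in this assay, at which 2 of the 3 values shown sit. For the compounds shown here, the one readable step is an at least 1.1-fold higher number from compound 1 to compound 3 (0.06 log units; that floor lies within the scatter), so cyclohexylamino in place of piperidin-1-yl on the carbonyl carbon gives no shift that can be told from the scatter.

Going by these compounds, whether 1-methylpiperidin-4-yl and cyclohexyl differ at all in this assay stays open, since any difference would lie beyond the limit. Also open, on these data alone, is whether a different group on this amide, such as a longer chain ending in an amine or a carboxylic acid, would give a value clearly lower than that of compound 1.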